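Sulfonamide Heterocycle Swap on the Thiourea Series

The source may hold more compounds than are shown below. What is called first, only, known or untested is meant among the compounds shown, and "the series" means these compounds.

Three analogues have numbers in a functional assay on LoVo cells (Homo sapiens) for antiproliferative activity, read by sulforhodamine B assay, with a stated time of 48 h; on this read-out lower numbers stand for stronger inhibition and higher numbers for weaker inhibition. Compound 1 `O=C(Nc1ccccc1)Nc1ccc(S(=O)(=O)Nc2ccnc3cc(C(F)(F)F)ccc23)cc1` gives 30200 nM. Compound 2 `Cc1noc(NS(=O)(=O)c2ccc(N/C(S)=N\c3ccnc4cc(C(F)(F)F)ccc34)cc2)c1C` gives 67100 nM, the second highest of the three; compound 3 `O=S(=O)(Nc1ccccn1)c1ccc(N/C(S)=N\c2ccnc3cc(C(F)(F)F)ccc23)cc1` gives 87500 nM. For the measured compounds named here, the only single-place step measured, a 1.3-fold higher number from compound 2 to compound 3 (0.12 log units; within the scatter), lies within the scatter. Compound 4 `Cc1cc(C)nc(NS(=O)(=O)c2ccc(N/C(S)=N\c3ccnc4cc(C(F)(F)F)ccc34)cc2)n1` carries the change (4,6-dimethylpyrimidin-2-yl in place of 3,4-dimethyl-1,2-oxazol-5-yl on a sulfonamide nitrogen). This again exchanges the group on the sulfonamide nitrogen for another aromatic ring, so the move from compound 2 to compound 3 is the step that bears on it, and no change beyond the scatter is expected. For compound 4 the step is estimated as a 1.0-fold higher number from compound 2 to compound 4 (0.02 log units; within the scatter). Compound 4 is therefore expected at 70000 nM, within 35000 nM to 140000 nM.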

Compound 4, half-maximal inhibitory concentration: 40200 nM
Compound 4: the middle estimate sits 1.7-fold (0.24 log units) above what was measured, and the stated range covers the measured number.
By their numbers in this assay, from the lowest: compounds 1, 4, 2 and 3 (each within the scatter of the next, the first and the last beyond it).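

For the compounds shown here, on the sulfonamide nitrogen in this assay, 4,6-dimethylpyrimidin-2-yl in place of pyridin-2-yl gives a 2.2-fold lower number from compound 3 to compound 4 (0.34 log units; beyond the scatter), the first step at this position to clear the scatter, so the choice of aromatic ring can register here, if only modestly. Against 3,4-dimethyl-1,2-oxazol-5-yl, the same group gives a 1.7-fold lower number from compound 2 to compound 4 (0.22 log units; within the scatter), which does not separate the two. No supporting data account for the modest step. Still open, going by these compounds, is whether a non-aromatic group on this nitrogen, such as a methyl or an aminoethyl chain, moves the number at all.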